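Pentyl in Place of 4-Acetylphenyl on a Shared Core

This account rests on a few compounds, and the source may have more. Where it says the series, first, only, none or still open, it means among the compounds named here.

Of the compounds shown here, three with a shared core have been measured in a functional assay on A549 cells (Homo sapiens) for antiproliferative activity, read by MTT assay; a higher number here means a weaker inhibitor, a lower number a stronger inhibitor. Compound 1 `COc1ccc(-n2cc(COc3ccc(/C=C/C(=O)c4cc5c(cc4O)OC(C)(C)CC5)cc3)nn2)c([N+](=O)[O-])c1` gives 99500 nM, compound 2 `CC(=O)c1ccc(-n2cc(COc3ccc(/C=C/C(=O)c4cc5c(cc4O)OC(C)(C)CC5)cc3)nn2)cc1` gives 66300 nM, and compound 3 `CC1(C)CCc2c(ccc(C(=O)/C=C/c3ccc(OCc4cn(-c5ccc(Br)cc5)nn4)cc3)c2O)O1` gives 129000 nM. Compound 2 therefore lies within the scatter of both compound 1 and compound 3, and it holds no clear place among them. Compound 4 `CCCCCn1cc(COc2ccc(/C=C/C(=O)c3cc4c(cc3O)OC(C)(C)CC4)cc2)nn1` carries pentyl in place of 4-acetylphenyl on an aromatic nitrogen. Among the measured compounds shown here, one measured step bears on this position: a 1.5-fold lower number from compound 1 to compound 2 (0.18 log units; within the scatter), a change within the scatter that exchanges one substituted phenyl group for another. For the measured compounds named here, no measured compound has an open chain at this position, so the evidence for the new change is thin and the range must stay wide. Nothing shown points in either direction in this assay, so no step beyond the scatter is expected. The expected result is a 1.2-fold higher number from compound 2 to compound 4 (0.08 log units; within the scatter). For compound 4 the estimated value is 80000 nM, with an expected range of 30000 nM to 200000 nM.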

Compound 4, half-maximal inhibitory concentration: 91300 nM
The estimate for compound 4 lay 1.1-fold (0.06 log units) below the measured number; measured number inside the range.
By their numbers in this assay, from the lowest: compounds 2, 4, 1 and 3 (each within the scatter of the next).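

In this assay, pentyl brings an open chain to this aromatic nitrogen, and replacing the ring-bearing 4-acetylphenyl gives a 1.4-fold higher number from compound 2 to compound 4 (0.14 log units; within the scatter), while replacing 4-methoxy-2-nitrophenyl gives a 1.1-fold lower number from compound 1 to compound 4 (0.04 log units; within the scatter). Both steps lie within the scatter, so among these compounds, a six-membered aromatic ring on this nitrogen is not required for a number in the range of compound 1 and compound 2, and removing the acceptor of 4-acetylphenyl brings no step beyond the scatter. Nothing available explains this result.

The compounds shown leave open whether any group at this nitrogen can move the number beyond the scatter. A shorter or longer chain, or a chain ending in an amine or a carboxylic acid, would test this.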